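A few compounds are considered here, and "the series" means these few. Any claim that something is new, unique, unknown or untested is made for them only; others in the source may bear on it.

Working notes on the series. Compound 1 `Cc1ccc(-c2c3c(nc(C)c2[C@H](OC(C)(C)C)C(=O)O)CCN(c2ccc(-c4ccccc4)cc2)C3)cc1` has been tested in an ADME assay on MT2 cells (Homo sapiens) for cytotoxicity, read by XTT assay, with a stated time of 4 days; a lower number here means that less compound is tolerated, a higher number that more compound is tolerated. In this assay compound 1 gives > 40000 nM, which is a limit of the assay and not a number. Compound 2 `Cc1ccc(-c2c3c(nc(C)c2C(OC(C)(C)C)C(=O)O)CCN(Cc2ccccc2-c2ccccc2)C3)cc1` gives in this assay > 40000 nM, again a limit. Compound 3 `Cc1nc2c(c(-c3cc(F)c4c(c3C)CCCO4)c1[C@H](OC(C)(C)C)C(=O)O)CN(CCCc1ccc(F)cc1)CC2` gives in this assay > 40000 nM, also a limit. Compound 1 therefore stands where every measured member of the series stands, at the limit of > 40000 nM in this assay, at which 3 of the 3 values shown sit, and nothing in the numbers separates it from compound 2 or compound 3.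

Compound 4 `Cc1ccc(-c2c3c(nc(C)c2[C@H](OC(C)(C)C)C(=O)O)CCN(Cc2ccccc2)C3)cc1` differs from compound 1 in one place: benzyl in place of 4-phenylphenyl on an amine nitrogen in a ring. Among the measured compounds shown here, no step between measured compounds is available for a change of this kind. Because the limit of > 40000 nM in this assay, at which 3 of the 3 values shown sit, holds for all three measured compounds, no direction is expected, and the step from compound 1 to compound 4 is expected to be none beyond the scatter, a step that the limit leaves unreadable from compound 1 to compound 4. For compound 4 in this assay the expected value is 60000 nM, with a range from 30000 nM to 150000 nM, and most likely the assay will again report only a limit.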

Compound 4, half-maximal cytotoxic concentration: > 40000 nM
Compound 4: a limit, no number; the forecaster's own chance of this, stated with the estimate: 85%; the middle value is on the limit's open side.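

No step can be read between compound 1 and compound 4, because both results are limits and not numbers: the limit of > 40000 nM in this assay, at which 4 of the 4 values shown sit.

The compounds shown leave open where any of them would reach a half-maximal cytotoxic concentration in this assay, and whether benzyl and 4-phenylphenyl differ there at all.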